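Acid to diol on the core of a chlorophenyl-substituted triazinedione

The compounds below may be only part of what the source reports. "The series", "measured", "known", "first", "only" and "open" are said of these compounds alone.

Measured compounds:
compound 1, `CC(C)Oc1ccc(/N=c2\[nH]c(=O)n(CC(C)(C)C(=O)O)c(=O)n2Cc2ccc(Cl)cc2)cc1Cl`, 0.003
compound 2, `CC(C)Oc1ccc(Nc2nc(=O)n(CCO)c(=O)n2Cc2ccc(Cl)cc2)cc1Cl`, 0.001

The series is followed in an ADME assay on the whole organism (plasma, Rattus norvegicus) for protein binding, using cassette dosing, at a dose of 1 mg/kg; on this read-out lower numbers stand for a smaller free fraction and higher numbers for a larger free fraction. Within the data shown here, compound 1, with a 1-carboxy-1-methylethyl group on the chain carbon bound to an aromatic nitrogen, gives 0.003, the higher of the two numbers measured so far. Compound 2, which carries a shorter hydroxyethyl chain on the same nitrogen of the shared core, gives 0.001 in this assay; its number lies below that of compound 1 by a gap beyond the usual scatter.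

The step considered here goes from compound 1 to compound 3, `CC(C)Oc1ccc(/N=c2\[nH]c(=O)n(C[C@@H](O)CO)c(=O)n2Cc2ccc(Cl)cc2)cc1Cl`. The change is 1,2-dihydroxyethyl in place of 1-carboxy-1-methylethyl on a saturated chain carbon bound to an aromatic nitrogen. Among the measured compounds shown here, no step between two measured compounds isolates this change. Compound 2, whose chain likewise ends in a hydroxyl rather than a carboxylic acid, sits lower than compound 1 in this assay, and compound 3 is expected to fall in the same direction, with a step of a 2.0-fold lower number from compound 1 to compound 3 (0.30 log units; within the scatter), modest but likely beyond the scatter. For compound 3 the expected unbound fraction is 0.0015, within a range of 0.0006 to 0.004.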

Compound 3, unbound fraction: 0.001
The estimate for compound 3 lay 1.5-fold (0.18 log units) above the measured number, within the range that was stated.
By their numbers in this assay, from the lowest: compounds 2 and 3 (each within the scatter of the next); then compound 1.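

Replacing 1-carboxy-1-methylethyl with 1,2-dihydroxyethyl on a saturated chain carbon bound to an aromatic nitrogen gives a 3.0-fold lower number from compound 1 to compound 3 (0.48 log units; beyond the scatter) in this assay, and this is the only step shown that isolates a change at this position. In this assay compound 3 gives 0.001 and compound 2 gives 0.001 as well, so this read-out does not separate the 1,2-dihydroxyethyl chain from the hydroxyethyl chain, and both stand apart from the acid-bearing chain of compound 1 by a gap beyond the scatter. No measurement shown here explains the step.

The compounds shown leave open whether the step belongs to the carboxylic acid itself or to the rest of the 1-carboxy-1-methylethyl group, a question that a carboxyethyl chain without the two methyl groups, or a carboxylic acid on a longer chain, would address. They also leave open how a chain ending in an amine, or the opposite stereocentre of the 1,2-dihydroxyethyl group, would read in this assay on the shared core.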